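Triazole series: phenethyl in place of phenyl, seizure dose

A few compounds are considered here, and "the series" means these few. Any claim that something is new, unique, unknown or untested is made for them only; others in the source may bear on it.

Compound 1 `CCCCCCOc1ccc(-n2cnnc2CCCC)cc1`: 13.6 mg/kg in a functional assay on the whole organism (strain C57B/6) with Mus musculus as the target, in the maximal electroshock model; a higher number here means that more compound is needed for the effect, a lower number that less compound is needed
Compound 2 `CCCCCCCCCc1nncn1-c1ccc(OCCCCCC)cc1`: > 40 mg/kg
Compound 3 `CCCCCCOc1ccc(-n2cnnc2-c2ccccc2)cc1`: 19 mg/kg

The value of compound 2 is a limit of this assay (the limit of > 40 mg/kg in this assay, at which 1 of the 3 values shown sits). Compound 3 has the higher of the two plain numbers, yet a 1.4-fold higher number from compound 1 to compound 3 (0.15 log units; within the scatter) keeps compound 1 and compound 3 within the scatter of each other. Compound 4 `CCCCCCOc1ccc(-n2cnnc2CCc2ccccc2)cc1` is unmeasured; the change is phenethyl in place of phenyl on an aromatic carbon. Bearing on it are an at least 2.9-fold higher number from compound 1 to compound 2 (0.46 log units; beyond the scatter), where a longer chain raised the dose, and an at least 2.1-fold lower number from compound 2 to compound 3 (0.32 log units; beyond the scatter). Phenethyl carries more atoms than phenyl, so a modest rise is expected: compound 4 is expected to show a 1.4-fold higher number from compound 3 to compound 4 (0.14 log units; within the scatter). Compound 4 is estimated at 26 mg/kg, between 12 mg/kg and 55 mg/kg.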

Compound 4, dose for half-maximal effect: 27.4 mg/kg
Compound 4: middle estimate off by 1.1-fold (0.02 log units), on the low side, within the range that was stated.
By their numbers in this assay, from the lowest: compounds 1, 3 and 4 (each within the scatter of the next). At a limit, above all of these: compound 2.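

At this aromatic carbon, phenethyl and phenyl cannot be told apart in this assay: a 1.4-fold higher number from compound 3 to compound 4 (0.16 log units; within the scatter). A phenyl ring carried on the chain also stays level with the butyl group, with a 2.0-fold higher number from compound 1 to compound 4 (0.30 log units; within the scatter), so this position accepts a ring set away from the core as well as one attached directly. Compound 2 stands at a limit, so an at least 1.4-fold lower number from compound 2 to compound 4 (0.16 log units; that floor lies within the scatter) gives only a floor: the limit of > 40 mg/kg in this assay, at which 1 of the 4 values shown sits.

From the compounds shown here alone, whether a benzyl group or a chain ending in an amine would stay within the same scatter remains open.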